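The source may report more compounds than this note shows. Statements on the series, on what has been measured and on what is new or still open speak of the compounds shown alone.

Measured so far in a functional assay on BT-549 cells (Homo sapiens) for cytotoxicity, read by sulforhodamine B assay, with a stated time of 48 h; a higher number here means that more compound is tolerated, a lower number that less compound is tolerated:
compound 1 `ClCc1cccc(Cn2cnc3ncnc(Cl)c32)c1` gives 63100 nM
compound 2 `ClCc1ccc(Cn2cnc3nc(Cl)nc(Cl)c32)cc1` gives 6450 nM
compound 3 `ClCc1cccc(Cn2cnc3nc(Cl)nc(Cl)c32)c1` gives 4160 nM

Compound 1 and compound 3 share one core and differ by hydrogen in place of chloro on an aromatic carbon, a change that brought a 15-fold higher number from compound 3 to compound 1 (1.18 log units; beyond the scatter). Compound 2 has the other core; the difference between the two cores is not broken down here, and its value stands within the scatter of compound 3. Compound 4 `ClCc1ccc(Cn2cnc3ncnc(Cl)c32)cc1` has not yet been measured in this assay. It differs from compound 2 by hydrogen in place of chloro on an aromatic carbon, the same change as from compound 3 to compound 1. Within the data shown here, the expected step is a 12-fold higher number from compound 2 to compound 4 (1.09 log units; beyond the scatter), a large rise like the earlier one, because a 15-fold higher number from compound 3 to compound 1 (1.18 log units; beyond the scatter) is the only example of this change and it was beyond the scatter. Compound 4 is therefore expected to give about 80000 nM, likely between 25000 nM and 250000 nM.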

Compound 4, concentration lethal to 50% of the cells: 56200 nM
Compound 4: middle estimate off by 1.4-fold (0.15 log units), on the high side, within the range that was stated.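

Swapping chloro for hydrogen on the aromatic carbon between two ring nitrogen atoms brought an 8.7-fold higher number from compound 2 to compound 4 (0.94 log units; beyond the scatter) in this assay, and the size of this step matches the earlier one on the other core: the same change on two cores in this assay, a 15-fold higher number (1.18 log units; beyond the scatter) from compound 3 to compound 1 and an 8.7-fold higher number (0.94 log units; beyond the scatter) from compound 2 to compound 4, 1.7-fold (0.24 log units) apart, within the scatter of two such steps. Within these four compounds, then, the change carries from one core to the other and keeps its size. Two examples on closely related cores do not show that it would hold on a more distant core, and they do not explain why the number rises.

At this place the compounds shown carry only chloro or hydrogen, and an amine or a methoxy group there remains open. Going by these compounds, all four also keep the chloromethyl group, and what happens to the number without it is open too.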